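Swapping nitro for trifluoromethyl on an acrylonitrile scaffold

A few compounds are considered here, and "the series" means these few. Any claim that something is new, unique, unknown or untested is made for them only; others in the source may bear on it.

Measured so far:
compound 1, `CCOC(=O)/C(C#N)=C(/Nc1ccc([N+](=O)[O-])cc1)N[C@H](C)c1ccccc1`, 2.9%
compound 2, `CCOC(=O)/C(C#N)=C(/NNC(=O)c1cc(OC)c(OC)c(OC)c1)N[C@@H](C)c1ccccc1`, 3.2%

In a functional assay on PC-3 cells (Homo sapiens) for antiproliferative activity, read by MTT assay, with a stated time of 72 h, tested at 5 uM (on this read-out lower numbers stand for less inhibition and higher numbers for more inhibition at the one concentration tested (going by the name of the read-out)), compound 1 gives 2.9%. Compound 2 gives 3.2% in this assay. Compound 1 has the lowest of the two numbers, but its gap to compound 2 lies within the scatter, so the two cannot be told apart; both show almost no inhibition.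

Compound 3, `CCOC(=O)/C(C#N)=C(/Nc1ccc(C(F)(F)F)cc1)N[C@H](C)c1ccccc1`, has not been measured. It differs from compound 1 in one place: trifluoromethyl in place of nitro on an aromatic carbon. The change sits on an aromatic carbon of a six-membered aromatic ring of carbon only, para to a large group.

Going by the values given here, no measured pair shows what such a change does here. Given that compound 1 gives 2.9%, compound 3 is expected to stay near the bottom, with a step of a number 3.1 percentage points higher from compound 1 to compound 3 (within the scatter) that does not reach beyond the scatter. The estimate for compound 3 is 6%, between 0% and 22%.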

Compound 3, a percentage reported as inhibition, at one concentration (the size of the read-out at that concentration, not a potency): 59.4%
The estimate for compound 3 lay 53.4 percentage points below the measured number; the measured number lies above the stated range.
By their numbers in this assay, from the lowest: compounds 1 and 2 (each within the scatter of the next); then compound 3.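

In this assay, trifluoromethyl in place of nitro, on an aromatic carbon para to a large group, gives a number 56.5 percentage points higher from compound 1 to compound 3 (beyond the scatter). The earlier compounds shown here showed only almost no inhibition, whereas this single change shows that the group at this position can decide whether the core of compound 1 inhibits these cells at the one concentration tested. Nothing measured here gives a reason for this step.

One swap cannot tell whether the gain is special to trifluoromethyl, or whether a chlorine atom, a methyl group or an amine on the same carbon would also bring it. Also open, as far as these compounds go, is whether the gain would survive a change elsewhere in compound 3, such as a carboxylic acid in place of the ethyl ester.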